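From 4-fluorobenzyl to 2-methoxyethyl on the amide

The source may hold more compounds than are shown below. What is called first, only, known or untested is meant among the compounds shown, and "the series" means these compounds.

Measured so far in an ADME assay on cells (Keratinocyte, Homo sapiens) for inhibition, read by fluorescence, with stated times of 2 h and 72 h; on this read-out higher numbers stand for weaker inhibition and lower numbers for stronger inhibition
compound 1 `CC1=C2[C@H](/C=C(\C)C(=O)NCc3ccccc3)CC[C@@H](C)[C@H]2CC1` gives 9000 nM
compound 2 `CC1=C2[C@H](/C=C(\C)C(=O)NCc3ccccc3F)CC[C@@H](C)[C@H]2CC1` gives 8700 nM
compound 3 `CC1=C2[C@H](/C=C(\C)C(=O)NCc3ccc(F)cc3)CC[C@@H](C)[C@H]2CC1` gives 9600 nM

Compound 3 at 9600 nM sits level with the other two, all within the scatter. The steps of a 1.0-fold lower number from compound 1 to compound 2 (0.01 log units; within the scatter) and a 1.1-fold higher number from compound 1 to compound 3 (0.03 log units; within the scatter) and a 1.1-fold higher number from compound 2 to compound 3 (0.04 log units; within the scatter) all stay within the scatter and vary only fluoro on the aromatic ring.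

Compound 4 `COCCNC(=O)/C(C)=C/[C@@H]1CC[C@@H](C)[C@H]2CCC(C)=C12` differs by methoxymethyl in place of 4-fluorophenyl on a saturated chain carbon bound to an amide-type nitrogen in words: methoxymethyl in place of 4-fluorophenyl on a saturated chain carbon bound to an amide-type nitrogen. For the measured compounds named here, no measured step removes the aromatic ring, so these steps set no size for this change. A modest move to a higher number in this assay is expected, with wide uncertainty. The expected change is a 1.5-fold higher number from compound 3 to compound 4 (0.16 log units; within the scatter) in this estimate. Compound 4 is estimated at 14000 nM with an expected range from 7000 nM to 40000 nM for repeat measurements.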

Compound 4, half-maximal inhibitory concentration: "not active" (no number reported)
The entry for compound 4 holds no number; there is nothing to compare the estimate with.
By their numbers in this assay, from the lowest: compounds 2, 1 and 3 (each within the scatter of the next).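

For the compounds shown here, compound 4 is entered as "not active" with no number, so no step to it from compound 1, compound 2 or compound 3 can be read. No outside evidence bears on this result. The compounds shown leave open how far 2-methoxyethyl in place of 4-fluorobenzyl shifts the read-out.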